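A few compounds are considered here, and "the series" means these few. Any claim that something is new, unique, unknown or untested is made for them only; others in the source may bear on it.

Measured in a functional assay on MDA-MB-231 cells (Homo sapiens) for inhibition, read by sulforhodamine B assay, tested at 10 uM; a lower number here means less inhibition, a higher number more inhibition at the concentration tested (going by the name of the read-out):
compound 1 `CN1CCN(c2ccc(C3=NNC(c4ccc(N(C)C)cc4)C3)cc2)CC1`: 11.4%
compound 2 `CN1CCN(c2ccc(C3=NN(C(=O)c4ccc(F)cc4)C(c4ccc(N(C)C)cc4)C3)cc2)CC1`: 3.5%
compound 3 `CN1CCN(c2ccc(C3=NN(C(=O)c4ccc(C(F)(F)F)cc4)C(c4ccc(N(C)C)cc4)C3)cc2)CC1`: 55.4%

Compound 2 gives the lowest of the three numbers in this assay. Its nearest neighbour is compound 1, and the step of a number 7.9 percentage points lower from compound 1 to compound 2 (within the scatter) lies within the scatter, so these two cannot be ordered. Compound 3 stands furthest away: the step of a number 51.9 percentage points higher from compound 2 to compound 3 (beyond the scatter) is large, as is a number 44 percentage points higher from compound 1 to compound 3 (beyond the scatter).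

Compound 4 `CN(C)c1ccc(C2CC(c3ccc(-n4ccnc4)cc3)=NN2C(=O)c2ccc(F)cc2)cc1` is not yet measured in this assay. It differs from compound 2 by 1H-imidazol-1-yl in place of 4-methylpiperazin-1-yl on an aromatic carbon. Among the measured compounds shown here, none of the measured steps touches this part of the shared core; all three alter only the group on the amine nitrogen in a ring or the substituent on that group, and the (4-fluorophenyl)carbonyl of compound 2 is kept in compound 4. For the measured compounds named here, with no measured step bearing on the change, no shift beyond the scatter is expected, and compound 2 serves as the anchor. Compound 4 is expected to give 8% in this assay, within -5% to 25%. The expected step is a number 4.5 percentage points higher from compound 2 to compound 4 (within the scatter).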

Compound 4, a percentage reported as inhibition, at one concentration (the size of the read-out at that concentration, not a potency): 9.4%
Estimate against measurement, compound 4: 1.4 percentage points below, within the range that was stated.
By their numbers in this assay, from the lowest: compounds 2, 4 and 1 (each within the scatter of the next); then compound 3.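

Among the compounds shown here, exchanging 4-methylpiperazin-1-yl for 1H-imidazol-1-yl, on an aromatic carbon para to a large group, gives the first reading at this position. In this assay, the step is a number 5.9 percentage points higher from compound 2 to compound 4 (within the scatter), so with the (4-fluorophenyl)carbonyl kept, a six-membered non-aromatic ring and a five-membered aromatic ring cannot be told apart here. No evidence at hand bears on the reason for this result.

Going by these compounds, it remains open whether compound 3 keeps its 55.4% when 1H-imidazol-1-yl replaces 4-methylpiperazin-1-yl; the exchange has been read only with the (4-fluorophenyl)carbonyl in place. Also open, on these data alone, is how a morpholine ring or an open-chain amine such as dimethylamino would read at this position.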